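Methyl on the Aromatic Ring of Two Related Cores

The source may hold more compounds than are shown below. What is called first, only, known or untested is meant among the compounds shown, and "the series" means these compounds.

Measured compounds in a functional assay on T47D cells (Homo sapiens) for inhibition, read by sulforhodamine B assay, with a stated time of 48 h; a higher number here means a weaker inhibitor of growth, a lower number a stronger inhibitor of growth:
compound 1, `COC(=O)[C@@]1(C)CCC=C2[C@@H]1CC[C@@H](C)[C@]2(C)Cc1c(C)[nH]c2ccccc12`, gives 17000 nM
compound 2, `COC(=O)[C@@]1(C)CCC=C2[C@@H]1CC[C@@H](C)[C@]2(C)Cc1c(C)[nH]c2ccc(C)cc12`, gives 31000 nM
compound 3, `COC(=O)[C@@]1(C)CC[C@@H]2C3=C1CC[C@@H](C)[C@]3(C)C[C@@H]1c3ccccc3N[C@H]21`, gives 35000 nM

Compound 1 and compound 2 share one core and differ only by methyl in place of hydrogen on an aromatic carbon. That change gave a 1.8-fold higher number from compound 1 to compound 2 (0.26 log units; within the scatter). Compound 3 carries a different core; the difference between the two cores is not broken down here. Compound 3 and compound 2 stand within the scatter of each other, while compound 3 sits beyond the scatter from compound 1.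

Compound 4, `COC(=O)[C@@]1(C)CC[C@@H]2C3=C1CC[C@@H](C)[C@]3(C)C[C@@H]1c3cccc(C)c3N[C@H]21`, is not yet measured. It differs from compound 3 by methyl in place of hydrogen on an aromatic carbon. For the measured compounds named here, this is the same kind of change as the one from compound 1 to compound 2, though the surroundings differ: in compound 2 the aromatic carbon is part of a fused or bridged system of two rings, meta to a fused ring and para to a fused ring, whereas in compound 4 it is part of a fused or bridged system of five rings, ortho to a fused ring and meta to a fused ring.

Because the earlier change gave a 1.8-fold higher number from compound 1 to compound 2 (0.26 log units; within the scatter), a step of similar size is expected from compound 3 to compound 4, namely a 1.3-fold higher number from compound 3 to compound 4 (0.11 log units; within the scatter). Compound 4 is therefore estimated to give 45000 nM in this assay, likely between 20000 nM and 100000 nM.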

Compound 4, concentration for 50% growth inhibition: 29000 nM
Compound 4: the middle estimate sits 1.6-fold (0.19 log units) above what was measured, within the range that was stated.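

In this assay, methyl in place of hydrogen on an aromatic carbon gave a 1.2-fold lower number from compound 3 to compound 4 (0.08 log units; within the scatter), so on the core of compound 3, as on the core of compound 1, this change stayed within the scatter. The two steps, set side by side, do not differ by more than repeated measurements of this kind would allow: the same change on two cores in this assay, a 1.8-fold higher number (0.26 log units; within the scatter) from compound 1 to compound 2 and a 1.2-fold lower number (0.08 log units; within the scatter) from compound 3 to compound 4, 2.2-fold (0.34 log units) apart, within the scatter of two such steps. This shows that the methyl moved the number little on either core, but it does not show that the step carries over from one core to the other in size or direction, as each core offers a single small step and the methyl stands in different surroundings on each.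

The compounds shown carry only hydrogen or methyl at these aromatic carbons, so it stays open what a chlorine atom, a methoxy group or an amine would do there on either core. Going by these compounds, it also stays open whether methyl on another aromatic carbon of either core would give a step beyond the scatter.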